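The compounds below may be only part of what the source reports. "The series", "measured", "known", "first", "only" and "open" are said of these compounds alone.

Working notes on the series. The shared core of compound 3 `C=C1C[C@]23C[C@@]1(O)CC[C@H]2c1ccc(O)c(C)c1[C@@H]3Cn1cc(-c2ccc(C)cc2)nn1` carries a 4-methylphenyl on the triazole; compound 1 `C=C1C[C@]23C[C@@]1(O)CC[C@H]2c1ccc(O)c(C)c1[C@@H]3Cn1cc(-c2ccccc2)nn1` carries the bare phenyl, compound 2 `C=C1C[C@]23C[C@@]1(O)CC[C@H]2c1ccc(O)c(C)c1[C@@H]3Cn1cc(-c2ccc(OC)cc2)nn1` the 4-methoxyphenyl. In a functional assay on MCF7 cells (Homo sapiens) for cytotoxicity, read by MTT assay, with a stated time of 4 days (a lower number here means a stronger inhibitor, a higher number a weaker inhibitor), compound 1 gives > 20000 nM, which is a limit of the assay and not a number. In this assay compound 2 gives > 20000 nM, again a limit. In this assay compound 3 gives > 20000 nM, also a limit. Compound 3 therefore stands nowhere distinct: the limit of > 20000 nM in this assay, at which 3 of the 3 values shown sit, so the steps are unreadable: a step that the two limits leave unreadable from compound 1 to compound 2, a step that the two limits leave unreadable from compound 1 to compound 3, a step that the two limits leave unreadable from compound 2 to compound 3.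

Compound 4 `C=C1C[C@]23C[C@@]1(O)CC[C@H]2c1ccc(O)c(C)c1[C@@H]3Cn1cc(-c2ccc(Cl)cc2)nn1` differs from compound 3 as chloro in place of methyl on an aromatic carbon. The three measured steps, all substitutions on the same aromatic carbon, bear on it, but none has a readable size. Going by the values given here, no measured step justifies expecting a readable change in this assay; the expected step that the limit leaves unreadable from compound 3 to compound 4 is therefore written as none beyond the scatter. For compound 4 the estimate in this assay is 30000 nM, within a range of 8000 nM to 150000 nM, and most likely a limit again.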

Compound 4, half-maximal inhibitory concentration: > 20000 nM
Compound 4: no number, only a limit (the forecaster's own chance of this, stated with the estimate: 75%); the middle value lies beyond the limit too.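

In this assay, the steps linking compound 4 to compound 1, compound 2 and compound 3 cannot be read, and all values are limits of the assay: the limit of > 20000 nM in this assay, at which 4 of the 4 values shown sit.

The compounds shown leave open whether any group in this place on the shared core gives a number rather than a limit in this assay.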